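Methyl in place of methoxy, starting from a limit

The source may hold more compounds than are shown below. What is called first, only, known or untested is meant among the compounds shown, and "the series" means these compounds.

In an ADME assay on HEK-293T cells (Homo sapiens) for cytotoxicity, read by MTT assay, with a stated time of 48 h (a higher number here means that more compound is tolerated, a lower number that less compound is tolerated), compound 1 `Cn1cc(C2CC(c3ccccc3)=NN2C(=O)c2cccnc2)c2ccccc21` gives > 300000 nM, which is a limit of the assay and not a number. Compound 2 `COc1ccc(C(=O)N2N=C(c3ccccc3)CC2c2cn(C)c3ccccc23)cn1` gives > 300000 nM, again only a limit. Among the compounds with values here, the one measured step, a step that the two limits leave unreadable from compound 1 to compound 2, therefore offers no size to carry forward. Compound 3 `Cc1ccc(C(=O)N2N=C(c3ccccc3)CC2c2cn(C)c3ccccc23)cn1` has methyl in place of methoxy on an aromatic carbon. Within the data shown here, the only guide is the limit of > 300000 nM in this assay, at which 2 of the 2 values shown sit, so in this assay no step beyond the scatter is expected in either direction. The estimated step is a number no higher from compound 2 to compound 3 (the limit leaves the size open). For compound 3 the expected value is 300000 nM, with an estimated range from 100000 nM to 600000 nM.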

Compound 3, half-maximal cytotoxic concentration: 154000 nM
The estimate for compound 3 lay 1.9-fold (0.29 log units) above the measured number, within the range that was stated.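

Of the three compounds, only compound 3 gives a real number rather than a limit in this assay, so this place on the ring, next to the ring nitrogen, can produce a readable value. Methyl in place of methoxy gives an at least 1.9-fold lower number from compound 2 to compound 3 (0.28 log units; that floor lies within the scatter), and methyl in place of hydrogen gives an at least 1.9-fold lower number from compound 1 to compound 3 (0.28 log units; that floor lies within the scatter). Both steps start from a limit, so their true sizes stay open: the limit of > 300000 nM in this assay, at which 2 of the 3 values shown sit.

As far as these compounds go, whether a larger chain such as ethyl, or an amine or a carboxylic acid, would give a number at this place remains open.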